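Swapping phenyl for 2-phenylethenyl on an amide

The source may hold more compounds than are shown below. What is called first, only, known or untested is meant among the compounds shown, and "the series" means these compounds.

Measured in an ADME assay on L6 cells (Rattus norvegicus) for cytotoxicity; a higher number here means a weaker inhibitor, a lower number a stronger inhibitor:
- compound 1 `COc1cc2c(cc1C(C)OCCc1ccccc1)C=CC(C)(C)O2`: 123000 nM
- compound 2 `COc1cc2c(cc1C(C)OC/C=C/c1ccccc1)C=CC(C)(C)O2`: 64400 nM
- compound 3 `COc1cc2c(cc1C(C)NC(=O)c1ccccc1)C=CC(C)(C)O2`: 34800 nM

Compound 3, at 34800 nM, lies within the usual scatter of repeated measurements of compound 2, at 64400 nM. Compound 1, at 123000 nM, gives a clearly higher number than compound 3.

The unmeasured compound 4 `COc1cc2c(cc1C(C)NC(=O)/C=C/c1ccccc1)C=CC(C)(C)O2` differs from compound 3 in one place: 2-phenylethenyl in place of phenyl on a carbonyl carbon. In short, 2-phenylethenyl stands in place of phenyl on a carbonyl carbon.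

For the measured compounds named here, one measured step bears on this: a 1.9-fold lower number from compound 1 to compound 2 (0.28 log units; within the scatter). There too 2-phenylethenyl entered, but in place of benzyl and on a saturated chain carbon, so the parallel is loose, and that step stayed within the scatter. Going by the values given here, no measured pair shows this exact swap. In this assay a small step is therefore expected, leaning towards a lower number and perhaps no larger than the scatter. The expected step is a 1.4-fold lower number from compound 3 to compound 4 (0.14 log units; within the scatter). Compound 4 is estimated at 25000 nM, with an expected range of 10000 nM to 60000 nM.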

Compound 4, half-maximal inhibitory concentration: 107000 nM
For compound 4 the middle estimate is 4.3-fold (0.63 log units) below the measured one; measured number above the stated range.
By their numbers in this assay, from the lowest: compounds 3, 2, 4 and 1 (each within the scatter of the next, the first and the last beyond it).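

In this assay, the place on the carbonyl carbon proved sensitive to this change: putting 2-phenylethenyl in place of phenyl gives a 3.1-fold higher number from compound 3 to compound 4 (0.49 log units; beyond the scatter), which makes compound 4 the weaker inhibitor of the two. The earlier step, a 1.9-fold lower number from compound 1 to compound 2 (0.28 log units; within the scatter), brought in the same group on a saturated chain carbon, so the effect of 2-phenylethenyl does not carry over from that setting to the amide. Nothing measured here explains why the two settings differ.

Still open, from the compounds shown here alone, is whether the double bond or the extra carbons account for the rise, which a longer saturated chain ending in phenyl on the carbonyl carbon could help to separate. Also open, going by these compounds, is how an amine or a carboxylic acid on the phenyl ring of compound 3 would shift the number.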